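This account rests on a few compounds, and the source may have more. Where it says the series, first, only, none or still open, it means among the compounds named here.

Three compounds built on one shared core differ only in the group carried on the phenyl ring that sits on the ring nitrogen. Compound 1 `Cc1cc(/C=C2\SC(=S)N(c3cccc(O)c3)C2=O)c(C)n1-c1cccc(-c2nnn[nH]2)c1` gives 35600 nM in an ADME assay on MT2 cells (Homo sapiens) for cytotoxicity, read by XTT assay, with a stated time of 4 days; on this read-out lower numbers stand for higher toxicity in this test and higher numbers for lower toxicity in this test. Compound 2 `Cc1cc(/C=C2\SC(=S)N(c3cccc(Br)c3)C2=O)c(C)n1-c1cccc(-c2nnn[nH]2)c1` gives 22600 nM in this assay, and compound 3 `Cc1cc(/C=C2\SC(=S)N(c3cccc([N+](=O)[O-])c3)C2=O)c(C)n1-c1cccc(-c2nnn[nH]2)c1` gives 77000 nM. Compound 3 thus stands highest of the three numbers, the least toxic here: the step of a 2.2-fold higher number from compound 1 to compound 3 (0.34 log units; beyond the scatter) and the step of a 3.4-fold higher number from compound 2 to compound 3 (0.53 log units; beyond the scatter) are both modest, while the step of a 1.6-fold lower number from compound 1 to compound 2 (0.20 log units; within the scatter) stays within the scatter. Compound 4 `Cc1cc(/C=C2\SC(=S)N(c3ccc(C(F)(F)F)cc3)C2=O)c(C)n1-c1cccc(-c2nnn[nH]2)c1` has not yet been measured. Its change from compound 3 is 4-(trifluoromethyl)phenyl in place of 3-nitrophenyl on an amide-type nitrogen in a ring. Every measured step swaps the group on this same phenyl ring, and the whole spread of the three numbers is modest. None of them, though, brings in a trifluoromethyl group, so they show only how far this position has moved the numbers, not which way. Compound 4 is therefore expected to fall back toward the middle of the measured range, a step of a 2.2-fold lower number from compound 3 to compound 4 (0.34 log units; beyond the scatter) that is an estimate. The value expected for compound 4 is 35000 nM, with a range from 15000 nM to 80000 nM.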

Compound 4, half-maximal cytotoxic concentration: 27100 nM
Estimate against measurement, compound 4: 1.3-fold (0.11 log units) above; the measured number falls inside the stated range.
By their numbers in this assay, from the lowest: compounds 2, 4 and 1 (each within the scatter of the next); then compound 3.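

In this assay, for the compounds shown here, the first trifluoromethyl group at this position does not stay with compound 3 at the high end: a 2.8-fold lower number from compound 3 to compound 4 (0.45 log units; beyond the scatter) is a modest step. Compound 4 instead falls in with the others, as a 1.2-fold higher number from compound 2 to compound 4 (0.08 log units; within the scatter) and a 1.3-fold lower number from compound 1 to compound 4 (0.12 log units; within the scatter) both lie within the scatter, so among these four only 3-nitrophenyl stands apart from the rest. No measurement shown here gives a reason for this separation.

Going from 3-nitrophenyl to 4-(trifluoromethyl)phenyl changes both the group and its place on the phenyl ring, so the compounds shown cannot say which of the two matters. As far as these compounds go, it also remains open how this position would respond to an amine or a carboxylic acid on that phenyl ring.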